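Acetyl change on the longer linker: expectation for compound 4

The compounds below may be only part of what the source reports. "The series", "measured", "known", "first", "only" and "open" are said of these compounds alone.

Measured so far:
compound 1 `O=C(CCCCC1CCSS1)NCc1cn(CCCOc2ccc3ccc(=O)oc3c2)nn1` 39.2%
compound 2 `CC(=O)c1cc2ccc(OCCCn3cc(CNC(=O)CCCCC4CCSS4)nn3)cc2oc1=O` 37.5%
compound 3 `O=C(CCCCC1CCSS1)NCc1cn(CCCCCOc2ccc3ccc(=O)oc3c2)nn1` 64.5%

All three values come from a functional assay on PC-12 cells (Rattus norvegicus) for cytotoxicity, read by MTT assay, with stated times of 3 h and 2 h, tested at 5 uM; a higher number here means a stronger effect of the compound at the concentration tested, a lower number a weaker effect. Compound 2 differs from compound 1 only by acetyl in place of hydrogen on an aromatic carbon, and that change made a step of a number 1.7 percentage points lower from compound 1 to compound 2 (within the scatter). Compound 3 differs from compound 1 in more than one place; the difference between the two cores is not broken down here. In this assay compound 3 stands highest of the three, with its steps to compound 1 and compound 2 both beyond the scatter.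

Compound 4 `CC(=O)c1cc2ccc(OCCCCCn3cc(CNC(=O)CCCCC4CCSS4)nn3)cc2oc1=O` is not yet measured. It differs from compound 3 by acetyl in place of hydrogen on an aromatic carbon, the same change as from compound 1 to compound 2, at a place described in the same words. The step from compound 3 to compound 4 is therefore expected to be small, about a number 2.5 percentage points lower from compound 3 to compound 4 (within the scatter), resting on the earlier step of a number 1.7 percentage points lower from compound 1 to compound 2 (within the scatter). Compound 4 is accordingly estimated at 62%, between 48% and 76%.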

Compound 4, a percentage reported as activity, at one concentration (the size of the read-out at that concentration, not a potency): 22.2%
The estimate for compound 4 lay 39.8 percentage points above the measured number; the measured number lies below the stated range.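

In this assay, acetyl in place of hydrogen on an aromatic carbon gives a number 42.3 percentage points lower from compound 3 to compound 4 (beyond the scatter). The same change therefore does not carry over with the same size from the core of compound 1 to the core of compound 3, and the two steps differ: the same change on two cores in this assay, a number 1.7 percentage points lower (within the scatter) from compound 1 to compound 2 and a number 42.3 percentage points lower (beyond the scatter) from compound 3 to compound 4, 40.6 percentage points apart, beyond the scatter of two such steps With one pair on each core, this shows that the step depends on its core, but it does not show which difference between the two cores is responsible or what lies behind it.

The compounds shown leave open how an amine or a carboxylic acid in place of acetyl at this aromatic carbon would read on either core. Also open, as far as these compounds go, is which of the two steps the same change would resemble on a core with a longer chain than that of compound 3.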